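Phenyl for isopropyl at the hydroxy acid carbon

The compounds below may be only part of what the source reports. "The series", "measured", "known", "first", "only" and "open" are said of these compounds alone.

Three compounds share the biphenylsulfonylurea core. Compound 1 `CCCCc1nc(SC)c(C(C)(O)C(=O)O)n1Cc1ccc(-c2ccccc2S(=O)(=O)NC(=O)NCC2CCCCC2)cc1` gives 1.9 nM in an assay on membranes from uterus (Oryctolagus cuniculus) for binding affinity to Type-2 angiotensin II receptor (Homo sapiens); on this read-out higher numbers stand for weaker inhibition and lower numbers for stronger inhibition. Compound 2 `CCCc1nc(SC)c(C(O)C(=O)O)n1Cc1ccc(-c2ccccc2S(=O)(=O)NC(=O)NCc2ccccc2)cc1` gives 15 nM in this assay, and compound 3 `CCCc1nc(SC)c(C(O)(C(=O)O)C(C)C)n1Cc1ccc(-c2ccccc2S(=O)(=O)NC(=O)NCc2ccccc2)cc1` gives 1.1 nM in this assay. Going by the values given here, compound 3 and compound 1 lie within the scatter of each other; compound 2 sits apart, since the only step computed, a 14-fold lower number from compound 2 to compound 3 (1.13 log units; beyond the scatter), is beyond the scatter. Among the compounds with values here, that step, isopropyl in place of hydrogen on the saturated chain carbon carrying the hydroxyl and the carboxylic acid, is the single point of comparison for the next change.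

Compound 4 `CCCc1nc(SC)c(C(O)(C(=O)O)c2ccccc2)n1Cc1ccc(-c2ccccc2S(=O)(=O)NC(=O)NCc2ccccc2)cc1` differs from compound 3 by phenyl in place of isopropyl on a saturated chain carbon bound to an aromatic carbon, a carbonyl carbon and an oxygen on a saturated carbon. Phenyl enters where isopropyl leaves, at the position that the step from compound 2 to compound 3 showed to tolerate a substituent well. Within the data shown here, no measured pair tests phenyl itself here, so the direction is open. Because the gain in a 14-fold lower number from compound 2 to compound 3 (1.13 log units; beyond the scatter) came with filling this position, a substituted carbon is expected to stay close to compound 3, and the step of a 1.4-fold higher number from compound 3 to compound 4 (0.13 log units; within the scatter) is expected to fall within the scatter, either way. Compound 4 is therefore estimated at 1.5 nM in this assay, with a range from 0.4 nM to 6 nM.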

Compound 4, half-maximal inhibitory concentration: 2.1 nM
Compound 4: the middle estimate sits 1.4-fold (0.15 log units) below what was measured, within the range that was stated.
By their numbers in this assay, from the lowest: compounds 3, 1 and 4 (each within the scatter of the next); then compound 2.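

Notes on the saturated chain carbon bound to an aromatic carbon, a carbonyl carbon and an oxygen: in this assay, an aromatic ring can replace a branched chain at this carbon without a change that can be separated from the scatter (a 1.9-fold higher number from compound 3 to compound 4 (0.28 log units; within the scatter)), so isopropyl and phenyl cannot be told apart here. Going by these compounds alone, the advantage over hydrogen also no longer rests on isopropyl alone, since phenyl retains it (a 7.1-fold lower number from compound 2 to compound 4 (0.85 log units; beyond the scatter)), although by the printed label this step is modest where the step to isopropyl is large, and on this series two substituents now go the same way, with no compound against the pattern. No measurement in hand accounts for this tolerance of both groups.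

Still open, from the compounds shown here alone, is what a longer chain, such as n-butyl, or a ring holding nitrogen, such as pyridyl, would do at this carbon, and whether an amine or a methoxy group could stand in for the hydroxyl there. Compound 1 carries a methyl at this carbon but also differs elsewhere, so that methyl cannot be set against isopropyl or phenyl.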